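The source may report more compounds than this note shows. Statements on the series, on what has been measured and on what is new or still open speak of the compounds shown alone.

Compound 1 `Cc1ccccc1Nc1nc(NC2CC2)ncc1Cl`: > 100000 nM (a limit)
Compound 2 `Cc1ccccc1Nc1nc(NC2CCCCC2)ncc1Cl`: > 100000 nM (a limit)
Compound 3 `Cc1ccccc1Nc1nc(Nc2ccccc2)ncc1Cl`: > 100000 nM (a limit)

All three entries come from an ADME assay on L02 cells (Homo sapiens) for inhibition, read by CCK-8 assay, with a stated time of 48 h (a lower number here means a stronger inhibitor of growth, a higher number a weaker inhibitor of growth), and none of them is a number. For the measured compounds named here, the series so far stands at the limit of > 100000 nM in this assay, at which 3 of the 3 values shown sit. Compound 3 has only a limit, > 100000 nM, so its place within the series cannot be ranked.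

Compound 4 `Cc1ccc(Nc2ncc(Cl)c(Nc3ccccc3C)n2)cc1` changes compound 3 by methyl in place of hydrogen on an aromatic carbon, para to a large group, which turns phenyl into 4-methylphenyl: methyl in place of hydrogen on an aromatic carbon.

The measured steps that bear on this are a step that the two limits leave unreadable from compound 1 to compound 3, a step that the two limits leave unreadable from compound 2 to compound 3 and a step that the two limits leave unreadable from compound 1 to compound 2. All three are changes at the substituent on nitrogen, and none has a readable size. They therefore offer no size or direction to carry over, and no step beyond the scatter is expected in this assay. The expected change is a number no higher from compound 3 to compound 4 (the limit leaves the size open). The estimate for compound 4 is 100000 nM, with an expected range from 40000 nM to 200000 nM.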

Compound 4, concentration for 50% growth inhibition: > 100000 nM
Compound 4 was reported as a limit (the forecaster's own chance of this, stated with the estimate: 75%); the middle value sits exactly at the limit.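

In this assay, for the compounds shown here, compound 4 gives > 100000 nM, a limit and not a number, so no step from compound 1, compound 2 or compound 3 to compound 4 can be read. The compounds shown leave open whether any substituent change on the shared core gives a measurable value, and how large any step would be.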